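The source may hold more compounds than are shown below. What is called first, only, known or untested is meant among the compounds shown, and "the series" means these compounds.

Working notes on the thiazole acetic acid series, read in an in vitro functional assay on HEK285-7 cells for antagonist activity at prostaglandin D2 receptor 2 (Homo sapiens), read by BRET and beta-arrestin recruitment; a lower number here means a smaller maximal response, a higher number a larger maximal response.

Compound 1 `O=C(O)Cc1sc(Cc2ccccc2)nc1-c1ccc(Cl)cc1` carries a single benzyl-type ring on the saturated chain carbon and gives 50% in this assay. Compound 2 `O=C(O)Cc1sc(C(c2ccc(F)cc2)c2ccc(F)cc2)nc1-c1ccnc(N2CCC2)c1` gives 80% in this assay. Compound 3 `O=C(O)Cc1sc(C(c2ccccc2)c2ccc(Cl)cc2)nc1-c1ccc(Cl)cc1` gives 80% in this assay. Among the measured compounds shown here, the only single-point step measured is a number 30 percentage points higher from compound 1 to compound 3 (beyond the scatter); it is the one change at the saturated chain carbon bound to two aromatic carbons that the series holds. Compound 3 stands level with compound 2 at the digits shown, the two together the highest of the three numbers, and sits beyond the scatter above compound 1.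

Compound 4 `O=C(O)Cc1sc(C(c2ccccc2)c2ccccn2)nc1-c1ccc(Cl)cc1` differs from compound 3 by pyridin-2-yl in place of 4-chlorophenyl on a saturated chain carbon bound to two aromatic carbons. The step from compound 1 to compound 3 shows that a second aromatic ring at this carbon matters, but it does not tell what swapping one six-membered ring for another at the same place does; compound 2, with two 4-fluorophenyl rings, gives the same number as compound 3, which suggests the identity of the ring changes little once two are present. Compound 4 keeps two aromatic rings, so the step of a number 5 percentage points lower from compound 3 to compound 4 (within the scatter) is expected to stay within the scatter, leaning slightly lower. Compound 4 is estimated at 75%, with a range from 55% to 90%.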

Compound 4, largest response reached (reported as efficacy), in percent of the reference or control that the assay uses: 55%
Estimate against measurement, compound 4: 20 percentage points above; the range from low to high includes it.
By their numbers in this assay, from the lowest: compounds 1 and 4 (each within the scatter of the next); then compounds 2 and 3 (each within the scatter of the next).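

In this assay, the identity of the second ring on the saturated chain carbon bound to two aromatic carbons proves to matter: pyridin-2-yl in place of 4-chlorophenyl gives a number 25 percentage points lower from compound 3 to compound 4 (beyond the scatter) and so takes back most of the gain seen with 4-chlorophenyl in place of hydrogen, which was a number 30 percentage points higher from compound 1 to compound 3 (beyond the scatter) in the same read-out. Pyridin-2-yl in place of hydrogen gives a number 5 percentage points higher from compound 1 to compound 4 (within the scatter) and leaves those two compounds level within the scatter, so at this place a second six-membered aromatic ring does not by itself carry the higher number. No measurement to hand bears on why the two rings part in this way.

The step changes two things at once, the chlorine going and a ring nitrogen entering, and the compounds shown do not separate them; pyridin-3-yl, pyridin-4-yl or 5-chloropyridin-2-yl at the same carbon would address that. As far as these compounds go, whether pyridin-2-yl has the same effect on the core of compound 2 also stays open.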